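This account rests on a few compounds, and the source may have more. Where it says the series, first, only, none or still open, it means among the compounds named here.

Three compounds built on two closely related cores have been examined in an ADME assay on BJ cells (Homo sapiens) for cytotoxicity, read by luminescence, with a stated time of 72 h; a higher number here means that more compound is needed for the effect, a lower number that less compound is needed. Compound 1 `CCOC(=O)c1c(-c2cccc(-c3ccccc3)c2)[nH]c2cc(OC(C)C)ccc2c1=O` carries a phenyl on the pendant aromatic ring. In this assay compound 1 gives > 21500 nM, which is a limit of the assay rather than a number. Compound 2 `CCOC(=O)c1c(-c2cccc(OC)c2)[nH]c2cc(OC(C)C)ccc2c1=O` differs from compound 1 in one place: methoxy in place of phenyl on an aromatic carbon. In this assay compound 2 gives > 21500 nM, again a limit. The step from compound 1 to compound 2 is therefore a step that the two limits leave unreadable from compound 1 to compound 2. Compound 3 `CCOC(=O)c1c(-c2cccc(-c3ccccc3)c2)[nH]c2cc(OC)c(OC)cc2c1=O` keeps the phenyl of compound 1 but sits on a different core; the difference between the two cores is not broken down here. In this assay compound 3 gives > 21500 nM, once more a limit. What the three measured values have in common is the limit of > 21500 nM in this assay, at which 3 of the 3 values shown sit.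

Compound 4 `CCOC(=O)c1c(-c2cccc(OC)c2)[nH]c2cc(OC)c(OC)cc2c1=O` has not yet been measured in this assay. It stands to compound 3 exactly as compound 2 stands to compound 1, the same change in the same place: methoxy in place of phenyl on an aromatic carbon. Among the measured compounds shown here, the one measured instance of this change, from compound 1 to compound 2, left both compounds at the limit, so no readable size can be carried over. For the measured compounds named here, the step from compound 3 to compound 4 is expected to be a step that the limit leaves unreadable from compound 3 to compound 4, resting on (the limit of > 21500 nM in this assay, at which 3 of the 3 values shown sit), where every value so far sits. Compound 4 is estimated to give 30000 nM in this assay, most likely reported only as a limit, with an expected range from 15000 nM to 100000 nM.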

Compound 4, half-maximal effective concentration: > 21500 nM
Compound 4: only a limit was reported; the forecaster's own chance of this, stated with the estimate: 85%; the middle value lies beyond the limit too.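

Compound 3 and compound 4 both sit at a limit of the assay rather than at a number, so the change from phenyl to methoxy between them has no size that can be read: the limit of > 21500 nM in this assay, at which 4 of the 4 values shown sit.

The compounds shown leave open at what concentration, if any, each of the four would reach the effect in this assay and whether the pendant group or the core changes that concentration.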